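Sulfur substitution on the shared core: estimate for compound 4

This account rests on a few compounds, and the source may have more. Where it says the series, first, only, none or still open, it means among the compounds named here.

Measured so far:
compound 1 `Cn1nc(-c2nnc(SCCOc3ccccc3F)o2)cc1-c1ccc(C(F)(F)F)cc1` — 23100 nM
compound 2 `Cn1nc(-c2nnc(SCCc3ccc(F)cc3)o2)cc1-c1ccc(C(F)(F)F)cc1` — 25200 nM
compound 3 `Cn1nc(-c2ccc(C(F)(F)F)cc2)cc1-c1nnc(S)o1` — > 100000 nM

In a functional assay on MCF7 cells (Homo sapiens) for cytotoxicity, read by MTT assay, with a stated time of 24 h (a lower number here means a stronger inhibitor, a higher number a weaker inhibitor), compound 1 gives 23100 nM and compound 2 gives 25200 nM; the step of a 1.1-fold higher number from compound 1 to compound 2 (0.04 log units; within the scatter) is within the scatter. Compound 3, which carries only hydrogen on the sulfur, stands apart from these two. In this assay compound 3 gives > 100000 nM, which is a limit of the assay and not a number, the one case here that sits at the limit of > 100000 nM in this assay, at which 1 of the 3 values shown sits.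

Compound 4 `Cn1nc(-c2ccc(C(F)(F)F)cc2)cc1-c1nnc(SCc2cccc([N+](=O)[O-])c2)o1` differs from compound 3 by 3-nitrobenzyl in place of hydrogen on a sulfur. Within the data shown here, no measured step covers this change directly; the only measured step, between compound 1 and compound 2, concerns the far end of the chain on that sulfur and is within the scatter. What the values show is that both compounds carrying a group on the sulfur give a number where compound 3 gives only a limit, so compound 4 is expected to give a number rather than a limit. The estimated step from compound 3 to compound 4 is an at least 4.0-fold lower number from compound 3 to compound 4 (0.60 log units; beyond the scatter), toward a lower number. Compound 4 is estimated at 25000 nM in this assay, with a range from 8000 nM to 80000 nM.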

Compound 4, half-maximal inhibitory concentration: > 100000 nM
Compound 4: only a limit was reported (the forecaster's own chance of this, stated with the estimate: 25%); middle value at least 4.0-fold (0.60 log units) from the limit.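

In this assay compound 4 gives > 100000 nM, a limit of the assay and not a number, as compound 3 also does, so the step between compound 3 and compound 4 cannot be read: the limit of > 100000 nM in this assay, at which 2 of the 4 values shown sit.

The compounds shown leave open whether 3-nitrobenzyl in place of hydrogen on the sulfur changes the value at all.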